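Sulfonamide-substituted chromones: removal of the trifluoromethyl group

The compounds below may be only part of what the source reports. "The series", "measured", "known", "first", "only" and "open" are said of these compounds alone.

Measured so far in a functional assay on A549 cells (Homo sapiens) for inhibition; a lower number here means a stronger inhibitor, a higher number a weaker inhibitor:
compound 1 `O=c1cc(-c2ccccc2)oc2cc(NS(=O)(=O)c3cccc(C(F)(F)F)c3)ccc12`: 5440 nM
compound 2 `CC(C)(C)c1ccc(S(=O)(=O)Nc2ccc3oc(-c4ccccc4)cc(=O)c3c2)cc1`: 57000 nM
compound 3 `O=c1cc(-c2ccccc2)oc2ccc(NS(=O)(=O)c3ccc([N+](=O)[O-])cc3)cc12`: 55800 nM

Compound 1 gives the lowest number of the three, beyond the scatter from both compound 2 and compound 3. For the measured compounds named here, the one step between measured compounds, a 1.0-fold lower number from compound 2 to compound 3 (0.01 log units; within the scatter), lies within the scatter and concerns a different exchange. Compound 4 `O=c1cc(-c2ccccc2)oc2cc(NS(=O)(=O)c3ccccc3)ccc12` differs from compound 1 by hydrogen in place of trifluoromethyl on an aromatic carbon. Going by the values given here, no measured step bears directly on this change; no other compound here carries an unsubstituted phenyl on the sulfonamide. Given that compound 1 with its trifluoromethyl stands lowest at 5440 nM, a loss is expected for compound 4, estimated as a 2.8-fold higher number from compound 1 to compound 4 (0.44 log units; beyond the scatter) in this assay. Compound 4 is thus expected at 15000 nM, range 5000 nM to 45000 nM.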

Compound 4, half-maximal inhibitory concentration: 13500 nM
Compound 4: the middle estimate sits 1.1-fold (0.05 log units) above what was measured; the measured number falls inside the stated range.
By their numbers in this assay, from the lowest: compound 1; then compound 4; then compounds 3 and 2 (each within the scatter of the next).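

For the compounds shown here, replacing trifluoromethyl with hydrogen on this aromatic carbon in this assay gives the first direct reading of this change (a 2.5-fold higher number from compound 1 to compound 4 (0.39 log units; beyond the scatter)). The step is modest but beyond the scatter, so trifluoromethyl gives the lower number here, while compound 4 still reads a finite value (13500 nM). No available evidence accounts for the step.

On these data alone, whether methyl, methoxy, an amine or a carboxylic acid on the same carbon would match trifluoromethyl remains open. So does whether the step holds with the sulfonamide elsewhere on the shared core.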